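Replacing the dimethoxyphenyl on a pyrazole sulfonamide series

This account rests on a few compounds, and the source may have more. Where it says the series, first, only, none or still open, it means among the compounds named here.

The study covers a small set of compounds sharing one core. Compound 1 `COc1ccc(OC)c(-c2cc(-c3ccccc3)nn2-c2ccc(S(N)(=O)=O)cc2)c1`, compound 2 `COc1ccc(OC)c(-c2cc(-c3ccccc3)nn2-c2ccc(S(=O)(=O)NC(C)=O)cc2)c1` and compound 3 `COc1ccc(OC)c(-c2cc(-c3ccc(Cl)cc3)nn2-c2ccc(S(=O)(=O)NC(C)=O)cc2)c1` have been measured in a functional assay on cells (Cancer cell lines, Homo sapiens) for cytotoxicity, read by sulforhodamine B assay, with a stated time of 48 h; a higher number here means a weaker inhibitor of growth, a lower number a stronger inhibitor of growth. Compound 1 gives 40700 nM, compound 2 gives 49800 nM and compound 3 gives 52600 nM. Compound 2 stands in the middle of the three numbers, with compound 3 nearest and compound 1 furthest, and every gap among them lies within the scatter: a 1.2-fold higher number from compound 1 to compound 2 (0.09 log units; within the scatter), and a 1.1-fold higher number from compound 2 to compound 3 (0.02 log units; within the scatter).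

Compound 4 `CC(=O)NS(=O)(=O)c1ccc(-n2nc(-c3ccccc3)cc2C2=CC(=O)C=CC2=O)cc1` has not yet been measured. It differs from compound 2 in one place: a group of 8 heavy atoms (6 carbon, 2 oxygen; one six-membered non-aromatic ring of carbon only) in place of a group of 10 heavy atoms (8 carbon, 2 oxygen; one six-membered aromatic ring of carbon only), on an aromatic carbon.

Neither measured step touches this position. The step from compound 1 to compound 2 changes the sulfonamide nitrogen, and the step from compound 2 to compound 3 changes the phenyl on the other side of the core. Both were within the scatter, so there is no measured guide to how this assay responds to a change on the aromatic carbon in question. On that basis the step from compound 2 to compound 4 is expected to be a 1.7-fold lower number from compound 2 to compound 4 (0.22 log units; within the scatter), with wide uncertainty. Compound 4 is estimated at 30000 nM, with a range from 6000 nM to 100000 nM.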

Compound 4, concentration for total growth inhibition: 100000 nM
The estimate for compound 4 lay 3.3-fold (0.52 log units) below the measured number, and the stated range covers the measured number.
By their numbers in this assay, from the lowest: compounds 1, 2, 3 and 4 (each within the scatter of the next, the first and the last beyond it).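

At this aromatic carbon of the five-membered aromatic ring, next to the ring nitrogen, this assay now has its first reading of a change: the 2,5-dimethoxyphenyl gives way to a six-membered non-aromatic ring of carbon only, with a 2.0-fold higher number from compound 2 to compound 4 (0.30 log units; within the scatter). The aromatic ring with its two methoxy groups can therefore be replaced here without a step beyond the scatter, although the entering group differs from it in both ring type and heavy-atom count, so this single step shows no measurable dependence of the assay on either difference. No measurement available here accounts for this outcome or links it to any property of the two groups.

The compounds shown leave open whether a plain phenyl, a group carrying an amine or a carboxylic acid, or a longer chain at this carbon would give a step beyond the scatter. They also leave open whether the same replacement would give a similar step with the unsubstituted sulfonamide of compound 1 or the chloro-substituted phenyl of compound 3.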